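The source may hold more compounds than are shown below. What is called first, only, known or untested is meant among the compounds shown, and "the series" means these compounds.

Working notes on this series. In an ADME assay on the whole organism (plasma) for pharmacokinetics, with Rattus norvegicus as the target (a lower number here means slower removal, a higher number faster removal of the compound), compound 1 `CS(=O)(=O)Nc1n[nH]c2c1CN([C@H]1CO[C@H](c3cc(F)ccc3F)[C@@H](N)C1)C2` gives 16 mL/min/kg and compound 2 `CCS(=O)(=O)Nc1n[nH]c2c1CN([C@H]1CO[C@H](c3cc(F)ccc3F)[C@@H](N)C1)C2` gives 12 mL/min/kg. Compound 2 therefore stands within the usual scatter of compound 1, and these two numbers are all that is in hand. Compound 3 `N[C@H]1C[C@@H](N2Cc3[nH]nc(NS(=O)(=O)C4CC4)c3C2)CO[C@@H]1c1cc(F)ccc1F` has no number yet. Its difference from compound 2 is cyclopropyl in place of ethyl on a sulfonyl sulfur. Within the data shown here, one measured step bears on this change, as it also alters the group on the sulfonyl sulfur: a 1.3-fold lower number from compound 1 to compound 2 (0.12 log units; within the scatter), with methyl in place of hydrogen on a saturated chain carbon bound to a sulfonyl sulfur. That step stays within the scatter, so no step beyond the scatter is expected in this assay, in either direction. The expected step is no change at the digits printed from compound 2 to compound 3 (within the scatter). Compound 3 is estimated at 12 mL/min/kg, with an expected range of 6.5 mL/min/kg to 22 mL/min/kg.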

Compound 3, clearance: 24 mL/min/kg
The estimate for compound 3 lay 2.0-fold (0.30 log units) below the measured number; the whole stated range lies below it.
By their numbers in this assay, from the lowest: compounds 2, 1 and 3 (each within the scatter of the next).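

In this assay a three-membered ring on the sulfonyl sulfur can now be read against two open groups: a 2.0-fold higher number from compound 2 to compound 3 (0.30 log units; within the scatter) and a 1.5-fold higher number from compound 1 to compound 3 (0.18 log units; within the scatter). Methyl, ethyl and cyclopropyl on this sulfur thus give no step beyond the scatter across compound 1, compound 2 and compound 3, a statement limited to these three compounds. Nothing available explains the numbers of this series.

From the compounds shown here alone, whether a longer chain such as propyl, a branched group such as isopropyl, or an amine such as dimethylamino on the sulfonyl sulfur would give a step beyond the scatter in this assay remains open. Also open, going by these compounds, is whether the change from ethyl to cyclopropyl would read the same with any other change on the shared core.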